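Adding methylsulfanyl to the acetamido group of compound 2

The source may hold more compounds than are shown below. What is called first, only, known or untested is meant among the compounds shown, and "the series" means these compounds.

In a functional assay with Oryctolagus cuniculus as the target (on this read-out lower numbers stand for stronger inhibition and higher numbers for weaker inhibition), compound 1 `COc1ccc(-c2nc(/N=C(\N)NC3CCCCC3)sc2-c2ccc(OC)cc2)cc1` reads > 1000 nM, which is a limit of the assay and not a number. Going by the values given here, compound 2 `COc1ccc(-c2nc(CNC(C)=O)sc2-c2ccc(OC)cc2)cc1` gives 15 nM, the only true number so far. Compound 3 `COc1ccc(-c2nc(CNC(=O)CSC)sc2-c2ccc(OC)cc2)cc1` has not yet been measured. It carries methylsulfanyl in place of hydrogen on a saturated chain carbon bound to a carbonyl carbon, and the difference counts as methylsulfanyl in place of hydrogen on a saturated chain carbon bound to a carbonyl carbon. Among the compounds with values here, only one measured step exists, an at least 66-fold lower number from compound 1 to compound 2 (1.82 log units; beyond the scatter). That step is large, and it shows that the group on this aromatic carbon can matter a great deal. However, it replaces a whole group and is a poor guide to so small an addition. A modest loss of strength is therefore expected, an estimated 2.0-fold higher number from compound 2 to compound 3 (0.30 log units; within the scatter). Compound 3 is estimated at 30 nM, with an expected range from 6 nM to 150 nM.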

Compound 3, half-maximal inhibitory concentration: < 100 nM
Compound 3 ended at the assay's limit; the forecaster's own chance of this, stated with the estimate: 8%; the middle value does not contradict the limit.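

In this assay compound 3 gives < 100 nM, which is a limit of the assay and not a number. Going by these compounds alone, the one step that can be read is an at least 10-fold lower number from compound 1 to compound 3 (1.00 log units; beyond the scatter), so the acetamido group can carry methylsulfanyl on its saturated chain carbon bound to a carbonyl carbon and still keep a clear lead over the group of compound 1. The step from compound 2 to compound 3 cannot be read, so this result does not say whether the addition changes strength at all, only where the reading stops: the limit of < 100 nM in this assay, at which 1 of the 3 values shown sits.

From the compounds shown here alone, a true number for compound 3 remains open, and with it the size of the change from hydrogen to methylsulfanyl. Also open, going by these compounds, is how an amine or a carboxylic acid would read on this same chain carbon, or a longer chain in place of methylsulfanyl.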